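A few compounds are considered here, and "the series" means these few. Any claim that something is new, unique, unknown or untested is made for them only; others in the source may bear on it.

In a functional assay on isolated protein for agonist activity at Glucose-dependent insulinotropic receptor (Homo sapiens), read by HTRF and cAMP accumulation (a lower number here means a smaller maximal response, a higher number a larger maximal response), compound 1 `CC(C)(C)OC(=O)N1CCC(O[C@H]2CC[C@H](Oc3cnc(S(C)(=O)=O)cn3)CC2)CC1` gives 110%. Going by the values given here, compound 2 `CS(=O)(=O)c1cnc(O[C@H]2CC[C@H](OC3CCN(C(=O)OC4CCOC4)CC3)CC2)cn1` gives 105% in this assay, and the single measured step, a number 5 percentage points lower from compound 1 to compound 2 (within the scatter), leaves the two within the scatter, so compound 2 stands level with compound 1. Compound 3 `CS(=O)(=O)c1cnc(O[C@H]2CC[C@H](OC3CCN(C(=O)C4(C(F)(F)F)CCCC4)CC3)CC2)cn1` differs from compound 2 by a group of 9 heavy atoms (6 carbon, 3 fluorine; one five-membered non-aromatic ring of carbon only) in place of a group of 6 heavy atoms (4 carbon, 2 oxygen; one five-membered non-aromatic ring with 1 hetero atom), on a carbonyl carbon. Among the compounds with values here, no measured step covers this exchange; the one step known, a number 5 percentage points lower from compound 1 to compound 2 (within the scatter), also swapped a group at a carbonyl and moved nothing beyond the scatter. The step is therefore expected to be a number 3 percentage points lower from compound 2 to compound 3 (within the scatter), nothing beyond the scatter. Compound 3 is estimated at 102%, between 85% and 118%.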

Compound 3, largest response reached (Emax), in percent of the reference or control that the assay uses: 95%
Compound 3: the middle estimate sits 7 percentage points above what was measured; the range from low to high includes it.
By their numbers in this assay, from the lowest: compounds 3, 2 and 1 (each within the scatter of the next, the first and the last beyond it).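

Placing the group of 9 heavy atoms on the carbonyl carbon gives a number 10 percentage points lower from compound 2 to compound 3 (within the scatter) in this assay, so a group with no hydrogen-bond acceptors still gives a response at this place. Against the tert-butyl compound, the same group gives a number 15 percentage points lower from compound 1 to compound 3 (beyond the scatter), the first step at this place to pass the scatter, though only modestly. No evidence bears on the origin of this step.

Still open, on these data alone, is how an amine or a carboxylic acid on this carbonyl carbon would read in this assay. Also open, as far as these compounds go, is whether the trifluoromethyl group or the five-membered carbon ring accounts for the step.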